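Series notes: replacing the aryl group on the shared core

The compounds below may be only part of what the source reports. "The series", "measured", "known", "first", "only" and "open" are said of these compounds alone.

Compound 1 `CC(C)n1nc(-c2cc(-c3ccccc3)on2)c(C(N)=O)c1N` gives 236 nM in an assay on isolated protein for inhibition of proto-oncogene tyrosine-protein kinase receptor Ret (Homo sapiens), read by radiometric assay and 33P incorporation, in the presence of a further agent that is not named here (a lower number here means a stronger inhibitor, a higher number a weaker inhibitor), and it stands lowest of the two numbers recorded; its nearest neighbour is compound 2 `Cc1ccc(-c2cc(-c3nn(C(C)C)c(N)c3C(N)=O)no2)cc1`, which gives 1660 nM. For the measured compounds named here, the one step recorded, a 7.0-fold higher number from compound 1 to compound 2 (0.85 log units; beyond the scatter), is a methyl in place of hydrogen on an aromatic carbon of the phenyl that compound 1 carries.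

Compound 3 `CCc1cc(-c2nn(C(C)C)c(N)c2C(N)=O)no1` differs from compound 1 in another way: ethyl in place of phenyl on an aromatic carbon. Going by the values given here, no recorded step covers the loss of the phenyl itself; the step from compound 1 to compound 2 bears on it only indirectly, in that it shows the group at this position of the shared core is not indifferent to alteration, and that an alteration there moved the number by a modest but clear amount. Among the compounds with values here, with no closer precedent, the direction is uncertain, but a weakening beyond the scatter is the more likely outcome, and the range must be wide.

For compound 3 the expected value in this assay is 1200 nM, within 250 nM to 6000 nM, which corresponds to an expected step of a 5.1-fold higher number from compound 1 to compound 3 (0.71 log units; beyond the scatter).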

Compound 3, half-maximal inhibitory concentration: 631 nM
Estimate against measurement, compound 3: 1.9-fold (0.28 log units) above; measured number inside the range.
By their numbers in this assay, from the lowest: compound 1; then compound 3; then compound 2.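

Notes on the aromatic carbon next to the ring oxygen: exchanging phenyl for ethyl gives in this assay a 2.7-fold higher number from compound 1 to compound 3 (0.43 log units; beyond the scatter) and so costs less than the earlier methyl step might have suggested for a change that removes the whole ring. The same ethyl, set against the 4-methylphenyl group, gives a 2.6-fold lower number from compound 2 to compound 3 (0.42 log units; beyond the scatter) and places compound 3 between the two aryl compounds, so at this position an aromatic ring does not by itself give the lower number: phenyl in compound 1 stands below ethyl, while 4-methylphenyl in compound 2 stands above it. Nothing at hand gives a measured reason for this order among the three compounds.

The compounds shown leave open how the number responds along a series of alkyl groups at this position, from methyl through propyl to a longer chain such as hexyl, since ethyl is the only chain here. They also leave open how this position responds to a group carrying a heteroatom, such as an amine, a hydroxymethyl group or a carboxylic acid, in place of the carbon-only groups seen so far.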